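Working notes: from compound 1 to compound 4

A few compounds are considered here, and "the series" means these few. Any claim that something is new, unique, unknown or untested is made for them only; others in the source may bear on it.

Values in an ADME assay on LLC-MK2 cells (Macaca mulatta) for cytotoxicity, read by spectrophotometry and crystal violet staining, with a stated time of 4 days; on this read-out higher numbers stand for lower toxicity in this test and lower numbers for higher toxicity in this test:
- compound 1 `CC(C)n1ncc2c(C(=O)Nc3c(F)cccc3F)cc(-c3cccs3)nc21`: > 200000 nM
- compound 2 `CC(C)n1ncc2c(C(=O)Nc3ccccn3)cc(-c3ccccc3)nc21`: 12500 nM
- compound 3 `CC(C)n1ncc2c(C(=O)Nc3ccccn3)cc(-c3ccsc3)nc21`: 25000 nM

Compound 1 gives only a limit and no number, and it stands at the limit of > 200000 nM in this assay, at which 1 of the 3 values shown sits. Compound 4 `CC(C)n1ncc2c(C(=O)Nc3c(F)cc(F)cc3F)cc(-c3cccs3)nc21` is not yet measured. It differs from compound 1 by fluoro in place of hydrogen on an aromatic carbon, which turns 2,6-difluorophenyl into 2,4,6-trifluorophenyl.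

Going by the values given here, no measured step covers this change. Among the compounds with values here, the only step available, a 2.0-fold higher number from compound 2 to compound 3 (0.30 log units; within the scatter), concerns another group on another amide and stays within the scatter. It gives weak support at best, so no step beyond the scatter is expected in this assay, in either direction. A further limit is also expected to be a likely outcome.

The expected change is a number no higher from compound 1 to compound 4 (the limit leaves the size open).

For compound 4 the estimated value is 200000 nM, with an expected range from 70000 nM to 300000 nM.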

Compound 4, half-maximal cytotoxic concentration: > 200000 nM
Compound 4 was reported as a limit; the forecaster's own chance of this, stated with the estimate: 60%; the middle value sits exactly at the limit.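

Compound 1 and compound 4 both stand at a limit and not at a number, so no step between them can be read in this assay: the limit of > 200000 nM in this assay, at which 2 of the 4 values shown sit.

The compounds shown leave open whether 2,4,6-trifluorophenyl in place of 2,6-difluorophenyl changes the half-maximal cytotoxic concentration at all.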